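A few compounds are considered here, and "the series" means these few. Any claim that something is new, unique, unknown or untested is made for them only; others in the source may bear on it.

In a functional assay on HepG2 cells (Homo sapiens) for antiproliferative activity, read by CCK-8 assay, with a stated time of 72 h, tested at 8 uM (on this read-out higher numbers stand for a stronger effect at the one concentration tested and lower numbers for a weaker effect), compound 2 `Nc1ccccc1NC(=O)/C=C/c1ccc(Cn2cnc3c(Nc4cccc(OC(F)(F)F)c4)nc(Cl)nc32)cc1` gives 37.6%. Compound 1 `CC1CCN(c2nc(Cl)nc3c2ncn3Cc2ccc(/C=C/C(=O)Nc3ccccc3N)cc2)CC1` carries 4-methylpiperidin-1-yl in place of (3-(trifluoromethoxy)phenyl)amino on an aromatic carbon; in this assay compound 1 gives 32.2%, and the step is a number 5.4 percentage points lower from compound 2 to compound 1 (within the scatter). Compound 3 `Nc1ccccc1NC(=O)c1ccc(Cn2cnc3c(Nc4cccc(OC(F)(F)F)c4)nc(Cl)nc32)cc1` differs from compound 2 in its core by (2-aminophenyl)carbamoyl in place of 2-((2-aminophenyl)carbamoyl)ethenyl on an aromatic carbon; in this assay compound 3 gives 31.2%, a step of a number 6.4 percentage points lower from compound 2 to compound 3 (within the scatter). Compound 4 `CC1CCN(c2nc(Cl)nc3c2ncn3Cc2ccc(C(=O)Nc3ccccc3N)cc2)CC1` has not yet been measured. It differs from compound 3 by 4-methylpiperidin-1-yl in place of (3-(trifluoromethoxy)phenyl)amino on an aromatic carbon, which is the same change, at the same place, that leads from compound 2 to compound 1. A step of similar size is expected from compound 3 to compound 4, namely a number 4.2 percentage points lower from compound 3 to compound 4 (within the scatter), because the earlier change gave a number 5.4 percentage points lower from compound 2 to compound 1 (within the scatter), which lay within the scatter. Compound 4 is estimated to reach 27%, expected to fall between 17% and 38%.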

Compound 4, a percentage reported as inhibition, at one concentration (the size of the read-out at that concentration, not a potency): 65.3%
The estimate for compound 4 lay 38.3 percentage points below the measured number, and the stated range ends below it.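

On the core of compound 3, 4-methylpiperidin-1-yl in place of (3-(trifluoromethoxy)phenyl)amino gives a number 34.1 percentage points higher from compound 3 to compound 4 (beyond the scatter), so this change did not carry over from the core of compound 2: the same change on two cores in this assay, a number 5.4 percentage points lower (within the scatter) from compound 2 to compound 1 and a number 34.1 percentage points higher (beyond the scatter) from compound 3 to compound 4, 39.5 percentage points apart, beyond the scatter of two such steps. Likewise, (2-aminophenyl)carbamoyl in place of 2-((2-aminophenyl)carbamoyl)ethenyl gives a number 33.1 percentage points higher from compound 1 to compound 4 (beyond the scatter), unlike its step on the other pair: the same change on two cores in this assay, a number 6.4 percentage points lower (within the scatter) from compound 2 to compound 3 and a number 33.1 percentage points higher (beyond the scatter) from compound 1 to compound 4, 39.5 percentage points apart, beyond the scatter of two such steps. In this assay, the effect of each change therefore depended on the other across these four compounds, but this single set shows neither why nor whether the same holds on any other core.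

The compounds shown leave open whether the rise is specific to 4-methylpiperidin-1-yl or would also appear with piperidin-1-yl or morpholin-4-yl on the core of compound 4. As far as these compounds go, it also remains open whether the rise would survive replacing the chloro group with an amine.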